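Cyanophenyl for methoxyphenyl on a non-toxic aryl ether series

The source may hold more compounds than are shown below. What is called first, only, known or untested is meant among the compounds shown, and "the series" means these compounds.

Compound 1 `Cc1nc(C)c([C@H](OC(C)(C)C)C(=O)O)c(N2CCC(C)(C)CC2)c1-c1ccc(Cc2ccccc2)cc1` gives >= 20000 nM in a toxicity assay on MT2 cells (Homo sapiens) for cytotoxicity, read by XTT assay, with a stated time of 4 days (on this read-out lower numbers stand for higher toxicity in this test and higher numbers for lower toxicity in this test), a limit of the test rather than a number.
Compound 2 `COc1ccc(CCOc2ccc(-c3c(C)nc(C)c([C@H](OC(C)(C)C)C(=O)O)c3N3CCC(C)(C)CC3)cc2)cc1` gives >= 33500 nM in this assay, again a limit.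
Compound 3 `COc1cccc(CCOc2ccc(-c3c(C)nc(C)c([C@H](OC(C)(C)C)C(=O)O)c3N3CCC(C)(C)CC3)cc2)c1` gives >= 33500 nM in this assay, also a limit.

Compound 3 therefore stands only at a limit, as do the other two values shown; the limit of >= 20000 nM in this assay, at which 1 of the 3 values shown sits, and the limit of >= 33500 nM in this assay, at which 2 of the 3 values shown sit, mark where they sit. The steps a step that the two limits leave unreadable from compound 1 to compound 2, a step that the two limits leave unreadable from compound 1 to compound 3 and a step that the two limits leave unreadable from compound 2 to compound 3 cannot be read as sizes for this reason. Compound 4 `Cc1nc(C)c([C@H](OC(C)(C)C)C(=O)O)c(N2CCC(C)(C)CC2)c1-c1ccc(OCCc2ccc(C#N)cc2)cc1` differs from compound 3 by 4-cyanophenyl in place of 3-methoxyphenyl on a saturated chain carbon, two bonds along the chain from an oxygen on an aromatic ring. The closest measured comparison is the exchange of one methoxyphenyl for another between compound 2 and compound 3, which left both at a limit, so no step beyond the scatter is expected here either. The step of a number no higher from compound 3 to compound 4 (the limit leaves the size open) is estimated to be flat, with compound 4 most likely reported as a limit. Compound 4 is expected to give 33500 nM, in a range from 15000 nM to 60000 nM.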

Compound 4, half-maximal cytotoxic concentration: >= 33500 nM
Compound 4: only a limit was reported; the forecaster's own chance of this, stated with the estimate: 85%; the middle value lies on the limit itself.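

In this assay compound 4 gives >= 33500 nM, which is a limit of the test and not a number. Its steps from compound 1, compound 2 and compound 3 cannot be read as sizes. As far as these compounds go, whether these four compounds differ at all in toxicity in this assay stays open.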